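Chloro added on the urea aryl ring of compound 3

The compounds below may be only part of what the source reports. "The series", "measured", "known", "first", "only" and "open" are said of these compounds alone.

Three ureas share one core. Compound 2 `COc1cc(Nc2ncnc3c(NC(=O)Nc4ccc(Cl)c(Cl)c4)cccc23)cc(OC)c1` gives 6230 nM in a functional assay on RT-112 cells (Homo sapiens) for antiproliferative activity, read by MTT assay, with a stated time of 72 h; a lower number here means a stronger inhibitor of growth, a higher number a weaker inhibitor of growth; compound 1 `COc1cc(Nc2ncnc3c(NC(=O)Nc4cc(Cl)c(Cl)cc4Cl)cccc23)cc(OC)c1` gives 4890 nM; compound 3 `COc1cc(Nc2ncnc3c(NC(=O)Nc4ccc(C(F)(F)F)cc4)cccc23)cc(OC)c1` gives 3920 nM. The step of a 1.3-fold lower number from compound 2 to compound 1 (0.11 log units; within the scatter) comes from chloro in place of hydrogen on an aromatic carbon. The cores of compound 2 and compound 3 differ by 4-(trifluoromethyl)phenyl in place of 3,4-dichlorophenyl on an amide-type nitrogen, giving a 1.6-fold lower number from compound 2 to compound 3 (0.20 log units; within the scatter), and a 1.2-fold lower number from compound 1 to compound 3 (0.10 log units; within the scatter) completes the set.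

Compound 4 `COc1cc(Nc2ncnc3c(NC(=O)Nc4ccc(C(F)(F)F)cc4Cl)cccc23)cc(OC)c1` is unmeasured; it differs from compound 3 by chloro in place of hydrogen on an aromatic carbon. This is the same kind of change as that from compound 2 to compound 1, but the place differs: there the carbon was ortho to a large group, meta to a chloro group and para to a chloro group, here it is ortho to a large group and meta to a trifluoromethyl group. Because a 1.3-fold lower number from compound 2 to compound 1 (0.11 log units; within the scatter) stayed within the scatter, the expected step of a 1.2-fold lower number from compound 3 to compound 4 (0.07 log units; within the scatter) is likewise small. The estimate for compound 4 in this assay is 3300 nM, between 1600 nM and 7000 nM.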

Compound 4, concentration for 50% growth inhibition: 1080 nM
Compound 4: middle estimate off by 3.1-fold (0.49 log units), on the high side; measured number below the stated range.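

Chloro in place of hydrogen on an aromatic carbon does not carry a fixed step from one compound pair to another in this assay: the same change on two cores in this assay, a 1.3-fold lower number (0.11 log units; within the scatter) from compound 2 to compound 1 and a 3.6-fold lower number (0.56 log units; beyond the scatter) from compound 3 to compound 4, 2.8-fold (0.45 log units) apart, beyond the scatter of two such steps

With a 3.6-fold lower number from compound 3 to compound 4 (0.56 log units; beyond the scatter) and a 5.8-fold lower number from compound 2 to compound 4 (0.76 log units; beyond the scatter) and also a 4.5-fold lower number from compound 1 to compound 4 (0.66 log units; beyond the scatter) as its steps, compound 4 is the strongest inhibitor of growth among the four compounds. Two pairs do not show whether the gap follows the place of the chloro or the other groups on the ring, and they give no rule for the change.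

The compounds shown leave open whether methyl or fluoro in place of this chloro gives a similar step. They also leave open what an amine or a carboxylic acid on the same ring would give.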